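Swapping the aryl group on the piperazine of compound 1

The compounds below may be only part of what the source reports. "The series", "measured", "known", "first", "only" and "open" are said of these compounds alone.

Of the compounds shown here, three sharing one core have been tested in a functional assay on HL-60 cells (Homo sapiens) for inhibition, read by MTT assay, with a stated time of 72 h; a higher number here means a weaker inhibitor, a lower number a stronger inhibitor. Compound 1, with the structure `Cc1nc(-c2ccccc2)c(C(=O)N2CCN(c3cccc(C)c3C)CC2)o1`, gives 35 nM in this assay, the lowest of the three numbers. Compound 2, `COc1cc(OC)cc(N2CCN(C(=O)c3onc(C)c3-c3ccccc3)CC2)c1`, gives 152 nM, and compound 3, `CCc1nc(-c2ccc(F)cc2)c(C(=O)N2CCN(c3cccc(Cl)c3)CC2)o1`, gives 169 nM. Both of those numbers stand beyond the usual scatter from the number of compound 1, so compound 1 is the strongest inhibitor of the three as measured. Compounds 2 and 3 each differ from compound 1 in more than one place, so no single change can be read off from their numbers.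

Compound 4, `Cc1nc(-c2ccccc2)c(C(=O)N2CCN(c3ccc(F)cc3)CC2)o1`, has not yet been measured. It differs from compound 1 in one place: 4-fluorophenyl in place of 2,3-dimethylphenyl on an amine nitrogen in a ring. The rest of the molecule is unchanged.

Among the compounds with values here, with no measured pair that isolates this kind of change, the expected size of the step is uncertain. The expectation is a modest weakening, with the step from compound 1 to compound 4 estimated as a 2.6-fold higher number from compound 1 to compound 4 (0.41 log units; beyond the scatter), though a result within the scatter would not be surprising. Compound 4 is expected to give about 90 nM in this assay, most likely between 30 nM and 300 nM.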

Compound 4, half-maximal inhibitory concentration: > 1000 nM
Compound 4 gave a limit, no number (the forecaster's own chance of this, stated with the estimate: 0%); at least 11-fold (1.04 log units) between middle value and limit.
By their numbers in this assay, from the lowest: compound 1; then compounds 2 and 3 (each within the scatter of the next). At a limit, above all of these: compound 4.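

Replacing 2,3-dimethylphenyl with 4-fluorophenyl on this amine nitrogen in a ring gives an at least 28-fold higher number from compound 1 to compound 4 (1.45 log units; beyond the scatter) in this assay. Compound 4 carries no number, only a limit of the assay: the limit of > 1000 nM in this assay, at which 1 of the 4 values shown sits. Within the data shown here, with the rest of the molecule unchanged, this is the first reading of a single change, and it shows that the group on this nitrogen cannot be exchanged freely, something compounds 2 and 3 could not show because each differs from compound 1 in more than one place.

The change takes away two methyl groups and brings in a fluorine in a single step, so the compounds shown cannot tell whether the loss of the methyl groups, the arrival of the fluorine or both together lie behind the step. Among these compounds, how an unsubstituted phenyl, a phenyl carrying only one methyl group or a saturated ring such as cyclohexyl would read on this nitrogen also remains open, and those results would show how narrow the tolerance at this position really is.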